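Chalcone-type ethers: from a furan to a dichlorophenyl

This account rests on a few compounds, and the source may have more. Where it says the series, first, only, none or still open, it means among the compounds named here.

Compound 1 `CNC(=O)c1cc(Oc2ccc(C(=O)/C=C/c3ccco3)cc2)ccn1`: "not determined" (no result reported) in a functional assay on PC-3 cells (Homo sapiens) for cytotoxicity, read by MTT assay, with a stated time of 72 h; on this read-out lower numbers stand for stronger inhibition and higher numbers for weaker inhibition.
Compound 2 `CNC(=O)c1cc(Oc2ccc(C(=O)/C=C/c3ccc(Cl)cc3Cl)cc2)ccn1`: 9220 nM in this assay.
Compound 3 `CNC(=O)c1cc(Oc2ccc(C(=O)/C=C/c3cccc([N+](=O)[O-])c3)cc2)ccn1`: "not determined" (no result reported) in this assay.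

Compound 1 stands without a single number in this assay, and compound 3 likewise; only compound 2 gives a value. Compound 4 `CNC(=O)c1cc(Oc2ccc(C(=O)/C=C/c3cccc(Cl)c3Cl)cc2)ccn1` is the untested member of the set. It differs from compound 1 in one place: 2,3-dichlorophenyl in place of furan-2-yl on a double-bonded chain carbon bound to a double-bonded chain carbon. For the measured compounds named here, with no step between measured compounds available, the size of the step in this assay cannot be read from the data; the nearest guide is compound 2, whose value is 9220 nM. Compound 4 is therefore expected to lie near that number, and its estimated value is 8000 nM with a range from 3000 nM to 25000 nM.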

Compound 4, half-maximal inhibitory concentration: > 50000 nM
Compound 4 gave a limit, no number; the forecaster's own chance of this, stated with the estimate: 15%; at least 6.2-fold (0.79 log units) between middle value and limit.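

Compound 4 gives only a limit in this assay, not a number: the limit of > 50000 nM in this assay, at which 1 of the 4 values shown sits. With 2,3-dichlorophenyl in place of 2,4-dichlorophenyl on the chain, the change reads as an at least 5.4-fold higher number from compound 2 to compound 4 (0.73 log units; beyond the scatter). The two dichlorophenyl groups are therefore not interchangeable here, so carrying two chlorines does not by itself preserve the value of compound 2.

Steps involving compound 1 and compound 3 cannot be read, so the standing of furan-2-yl and the nitrophenyl group remains open. How a pyridine ring or a dimethylamino group would fare at this place is also unknown.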